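The compounds below may be only part of what the source reports. "The series", "measured", "known", "first", "only" and "open" are said of these compounds alone.

Working notes on the series. In an ADME assay on HepG2 cells (Homo sapiens) for cytotoxicity, read by luminescence, with a stated time of 72 h (a lower number here means that less compound is needed, a higher number that more compound is needed for the effect), compound 1 `CCOC(=O)c1c(-c2cccc(OCC)c2)[nH]c2cc(OC)ccc2c1=O` returns only a limit of the assay, > 21500 nM. Compound 2 `CCOC(=O)c1c(-c2cccc(OC(F)(F)F)c2)[nH]c2cc(OC)ccc2c1=O` likewise returns only a limit in this assay, > 21500 nM. The step that the two limits leave unreadable from compound 1 to compound 2 cannot be read because the limit of > 21500 nM in this assay, at which 2 of the 2 values shown sit, places both values at that limit. Compound 1 therefore has no numerical position among the values shown, only the limit. Compound 3 `CCOC(=O)c1c(-c2cccc(S(C)(=O)=O)c2)[nH]c2cc(OC)ccc2c1=O` differs from compound 1 in one place: methylsulfonyl in place of ethoxy on an aromatic carbon. Going by the values given here, the single measured step, a step that the two limits leave unreadable from compound 1 to compound 2, is unreadable, so it yields no size of step for this change in either direction. With both measured values at the limit, compound 3 is expected to sit there as well, an estimated step that the limit leaves unreadable from compound 1 to compound 3. The estimate for compound 3 in this assay is 30000 nM, with a range from 12000 nM to 100000 nM, most likely reported again only as a limit.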

Compound 3, half-maximal effective concentration: > 21500 nM
Compound 3 ended at the assay's limit; the forecaster's own chance of this, stated with the estimate: 85%; the middle value lies beyond the limit too.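

Going by these compounds alone, no step among compound 1, compound 2 and compound 3 can be read, and the change to methylsulfonyl yields no size of step from either of the other two compounds: the limit of > 21500 nM in this assay, at which 3 of the 3 values shown sit.

The compounds shown leave open whether any group at this place on the shared core gives a readable value in this assay at all.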